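This account rests on a few compounds, and the source may have more. Where it says the series, first, only, none or still open, it means among the compounds named here.

Measured compounds in this series:

compound 1, `COc1cc(C(=O)Nc2ccc(C)c(Nc3nccc(-c4cccnc4)n3)c2)ccc1OCCCCn1ccnc1`: 27100 nM
compound 2, `COc1ccc(C(=O)Nc2ccc(C)c(Nc3nccc(-c4cccnc4)n3)c2)cc1OCCCCn1ccnc1`: 18700 nM
compound 3, `Cc1ccc(NC(=O)c2cc(I)ccc2OCCCCn2ccnc2)cc1Nc1nccc(-c2cccnc2)n1`: 81700 nM

In a functional assay on K-562R cells (Homo sapiens) for cytotoxicity, read by XTT assay, with a stated time of 24 h (on this read-out higher numbers stand for weaker inhibition and lower numbers for stronger inhibition), compound 1 gives 27100 nM, the second highest of the three numbers. Compound 2 gives 18700 nM, and this value and that of compound 1 lie within the scatter of each other, so no order between them is claimed. Compound 3 gives 81700 nM, the highest number of the set and beyond the scatter from compound 1.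

Compound 4, `Cc1ccc(NC(=O)c2ccc(OCCCCn3ccnc3)c(I)c2)cc1Nc1nccc(-c2cccnc2)n1`, is not yet measured in this assay. It differs from compound 1 in one place: iodo in place of methoxy on an aromatic carbon. For the measured compounds named here, no pair of measured compounds differs only in this way, so the size of the step is open. Compound 3 also carries an iodo group and gives the highest number, but it is not a single-change partner of compound 1 or of compound 4, so its value is only a hint. The expectation is a moderate rise, possibly no larger than the scatter, as the step of a 1.5-fold higher number from compound 1 to compound 4 (0.17 log units; within the scatter). Compound 4 is estimated at 40000 nM, with a range from 15000 nM to 110000 nM.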

Compound 4, half-maximal inhibitory concentration: 52400 nM
Compound 4: the middle estimate sits 1.3-fold (0.12 log units) below what was measured; measured number inside the range.
By their numbers in this assay, from the lowest: compounds 2, 1, 4 and 3 (each within the scatter of the next, the first and the last beyond it).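

In this assay the series now has its first readable single change: iodo in place of methoxy on an aromatic carbon, ortho to a 4-(1H-imidazol-1-yl)butoxy group and meta to a large group, gives a 1.9-fold higher number from compound 1 to compound 4 (0.29 log units; within the scatter) and so does not separate the two compounds. At this position, then, the methoxy oxygen and its hydrogen-bond acceptor can be exchanged for iodo with no difference beyond the scatter on this read-out. No accompanying measurement bears on this step.

Going by these compounds, whether any other group at this place, such as an amine, a carboxylic acid or a fluoro group, would give a number beyond the scatter remains open. Also open, on these data alone, is whether this exchange would read the same with a longer chain in place of the 4-(1H-imidazol-1-yl)butoxy group.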